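From a primary amine to a diethylamino chain

This account rests on a few compounds, and the source may have more. Where it says the series, first, only, none or still open, it means among the compounds named here.

Compound 3 `Cc1ccccc1C(=O)Nc1ccc(S(=O)(=O)NC2CCN(C(=O)CCN)CC2)c2ccccc12` gives 11.3 nM in an assay on L1.2 cells for binding affinity to C-C chemokine receptor type 8 (Homo sapiens) (a higher number here means a weaker inhibitor, a lower number a stronger inhibitor), the lowest number among the compounds with a measured value here. Compound 1 `O=C(Nc1ccc(S(=O)(=O)N2CCOCC2)c2ccccc12)c1ccccc1` gives 7750 nM in this assay. Compound 2 `CCOC(=O)N1CCC(NS(=O)(=O)c2ccc(O)c3ccccc23)CC1` reached only a limit of this assay, > 5000 nM, so no number is known for it. Compound 4 `CCN(CC)CCCC(=O)N1CCC(NS(=O)(=O)c2ccc(NC(=O)c3ccccc3C)c3ccccc23)CC1` is the unmeasured compound, and it differs from compound 3 in one place: (diethylamino)methyl in place of amino on a saturated chain carbon, two bonds along the chain from a carbonyl carbon. Among the compounds with values here, the remaining compounds differ from compound 3 in several places at once, so no single step of this kind has been measured. Since the part of compound 3 that carries the rest of its structure is unchanged, the expected step from compound 3 to compound 4 in this assay, a 1.1-fold higher number from compound 3 to compound 4 (0.03 log units; within the scatter), is small and within the usual scatter. Compound 4 is therefore estimated to give 12 nM in this assay, expected between 3 nM and 50 nM.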

Compound 4, inhibition constant: 567 nM
For compound 4 the middle estimate is 47-fold (1.67 log units) below the measured one; measured number outside the range, above it.
By their numbers in this assay, from the lowest: compound 3; then compound 4; then compound 1.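

Replacing amino with (diethylamino)methyl on a saturated chain carbon, two bonds along the chain from a carbonyl carbon, gives a 50-fold higher number from compound 3 to compound 4 (1.70 log units; beyond the scatter) in this assay even though the rest of the structure is unchanged. Within the data shown here, this shows that the number is sensitive to the end of this chain, which the earlier compounds could not reveal. Nothing measured here explains the size of this step.

The change both lengthens the chain and replaces the primary amine with a diethylamino group, and the compounds shown do not separate these two parts. A longer chain ending in a primary amine, or the shorter chain ending in a diethylamino group, would separate them.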